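Anilide for ester on the chloro-bearing analogue

This account rests on a few compounds, and the source may have more. Where it says the series, first, only, none or still open, it means among the compounds named here.

Compound 3 `CCOC(=O)C1=C(C)NC(=O)NC1c1cn(-c2ccccc2)nc1-c1ccc(Cl)cc1` gives 68800 nM in a functional assay on MCF7 cells (Homo sapiens) for inhibition, read by sulforhodamine B assay, with a stated time of 24 h; on this read-out higher numbers stand for weaker inhibition of growth and lower numbers for stronger inhibition of growth; it stands second highest of the three numbers, with compound 1 `CCOC(=O)C1=C(C)NC(=O)NC1c1cn(-c2ccccc2)nc1-c1ccccc1` at 60800 nM as the nearest and compound 2 `CC1=C(C(=O)Nc2ccccc2)C(c2cn(-c3ccccc3)nc2-c2ccccc2)NC(=O)N1` at 80600 nM as the furthest, both within the scatter. Compound 4 `CC1=C(C(=O)Nc2ccccc2)C(c2cn(-c3ccccc3)nc2-c2ccc(Cl)cc2)NC(=O)N1` differs from compound 3 by anilino in place of ethoxy on a carbonyl carbon. Within the data shown here, the one measured step that bears on this change is a 1.3-fold higher number from compound 1 to compound 2 (0.12 log units; within the scatter), the same exchange made on the pair without chloro. The chloro step itself, a 1.1-fold higher number from compound 1 to compound 3 (0.05 log units; within the scatter), also stayed within the scatter. A step of comparable size is therefore expected, a 1.2-fold higher number from compound 3 to compound 4 (0.09 log units; within the scatter), leaning to a higher number but not beyond the scatter. For compound 4 the estimate is 85000 nM, with a range from 40000 nM to 180000 nM.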

Compound 4, concentration for 50% growth inhibition: 65500 nM
Compound 4: middle estimate off by 1.3-fold (0.11 log units), on the high side; the range from low to high includes it.
By their numbers in this assay, from the lowest: compounds 1, 4, 3 and 2 (each within the scatter of the next).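

In this assay anilino in place of ethoxy on the chloro-bearing core gives a 1.1-fold lower number from compound 3 to compound 4 (0.02 log units; within the scatter) and chloro in place of hydrogen on the anilide core gives a 1.2-fold lower number from compound 2 to compound 4 (0.09 log units; within the scatter) in the same notes. The ethoxycarbonyl to phenylcarbamoyl change now reads on two cores, without a shared direction: the same change on two cores in this assay, a 1.3-fold higher number (0.12 log units; within the scatter) from compound 1 to compound 2 and a 1.1-fold lower number (0.02 log units; within the scatter) from compound 3 to compound 4, 1.4-fold (0.14 log units) apart, within the scatter of two such steps. The chloro change also reads on two cores, likewise without a shared direction: the same change on two cores in this assay, a 1.1-fold higher number (0.05 log units; within the scatter) from compound 1 to compound 3 and a 1.2-fold lower number (0.09 log units; within the scatter) from compound 2 to compound 4, 1.4-fold (0.14 log units) apart, within the scatter of two such steps.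

No step shown at this carbonyl carbon or at the chloro position leaves the scatter. Going by these compounds, whether a carboxylic acid or a longer alkyl ester on the carbonyl carbon would do so remains open.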